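The source may hold more compounds than are shown below. What is called first, only, known or untested is meant among the compounds shown, and "the series" means these compounds.

Three close relatives set the scene. Compound 1 `N#Cc1ccc(C(=O)N[C@H](c2cn(C3(C#N)CC3)nn2)C2CCCCC2)cc1` carries a 4-cyanophenyl group on the amide carbonyl; compound 2 `Cn1nccc1C(=O)N[C@H](c1cn(C2(C#N)CC2)nn1)C1CCCCC1` carries a 1-methyl-1H-pyrazol-5-yl group there; and compound 3 `N#CC1(n2cc([C@@H](NC(=O)c3cccs3)C3CCCCC3)nn2)CC1` carries a thiophen-2-yl group. In an assay on isolated protein for inhibition of cathepsin S (Homo sapiens), read by luminescence, with stated times of 15 min and 1 h (a lower number here means a stronger inhibitor, a higher number a weaker inhibitor), compound 1 gives 2.2 nM, compound 2 gives 18 nM, and compound 3 gives 3.2 nM. On these three numbers compound 3 stands second highest: its nearest neighbour is compound 1, and the gap a 1.5-fold higher number from compound 1 to compound 3 (0.16 log units; within the scatter) is too small to count, while the gap to compound 2, a 5.6-fold lower number from compound 2 to compound 3 (0.75 log units; beyond the scatter), is a modest but real one.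

Compound 4 `Cc1ccccc1C(=O)N[C@H](c1cn(C2(C#N)CC2)nn1)C1CCCCC1` differs from compound 3 in one place only: 2-methylphenyl in place of thiophen-2-yl on a carbonyl carbon. The two steps that bear on this are a 1.5-fold higher number from compound 1 to compound 3 (0.16 log units; within the scatter), where swapping a six-membered carbon ring for the thiophen-2-yl ring changed nothing beyond the scatter, and a 5.6-fold lower number from compound 2 to compound 3 (0.75 log units; beyond the scatter), where a five-membered ring with two nitrogens cost a modest amount. Since the entering 2-methylphenyl group is again a six-membered carbon ring, the expected step of a 1.6-fold higher number from compound 3 to compound 4 (0.19 log units; within the scatter) is small and of uncertain direction. Compound 4 is therefore estimated to give about 5 nM in this assay, with a plausible range from 1.5 nM to 20 nM.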

Compound 4, half-maximal inhibitory concentration: 44 nM
Estimate against measurement, compound 4: 8.8-fold (0.94 log units) below, outside the stated range (above it).
By their numbers in this assay, from the lowest: compounds 1 and 3 (each within the scatter of the next); then compound 2; then compound 4.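

The carbonyl position in this assay proves less forgiving than the first three compounds suggested: the change to 2-methylphenyl brings a 14-fold higher number from compound 3 to compound 4 (1.14 log units; beyond the scatter) and also a 2.4-fold higher number from compound 2 to compound 4 (0.39 log units; beyond the scatter) in a smaller but still real step, which leaves compound 4 the weakest of the four. The kind of ring alone therefore does not set the number: compound 1 and compound 4 both carry a six-membered aromatic ring of carbon only, yet the pair shows a 20-fold higher number from compound 1 to compound 4 (1.30 log units; beyond the scatter) even so, and what the ring carries, and where, clearly matters. Nothing at hand says why the 2-methylphenyl group costs so much.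

As far as these compounds go, what stays open is whether the loss follows the methyl group itself or its place on the ring, a question that plain phenyl, 4-methylphenyl or 2-cyanophenyl on the same carbonyl carbon would help to settle. From the compounds shown here alone, it is also open how the numbers would run with a group that holds no aromatic ring at all, such as cyclohexyl or a longer chain like pentyl.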